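The source may report more compounds than this note shows. Statements on the series, on what has been measured and on what is new or still open speak of the compounds shown alone.

Within the data shown here, in a physicochemical assay for lipophilicity, read by HPLC, measured as octanol-water partition (a higher number here means a more lipophilic compound, a lower number a more polar compound), compound 1 `Oc1ccc(/C=C/c2cccc(O)c2)cc1` gives 2.08, the lower of the two numbers so far, and compound 2 `Oc1cccc(/C=C/c2ccccc2)c1` gives 3.22. Among the measured compounds shown here, the only measured step, a number 1.14 log units higher from compound 1 to compound 2 (beyond the scatter), is large and beyond the scatter; it puts hydrogen in place of hydroxy on an aromatic carbon. Compound 3 `COc1cccc(/C=C/c2ccc(O)cc2)c1` is still unmeasured, and its change is methyl in place of hydrogen on an oxygen on an aromatic ring, hydroxy to methoxy. For the measured compounds named here, the measured step bears on this only in part: compound 3 keeps the oxygen, and the hydroxy changed is not the one that compound 2 lacks. Both changes do remove a hydroxy, so the direction seen for compound 2 at 3.22 is expected to hold, at a smaller size. The expected step is a number 0.62 log units higher from compound 1 to compound 3 (beyond the scatter), probably beyond the scatter. Compound 3 is estimated at 2.7, with an expected range of 2.35 to 3.1.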

Compound 3, partition coefficient: 3.14
Compound 3: the middle estimate sits 0.44 log units below what was measured; measured number outside the range, above it.
By their numbers in this assay, from the lowest: compound 1; then compounds 3 and 2 (each within the scatter of the next).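

In this assay, hydroxy to methoxy gives a number 1.06 log units higher from compound 1 to compound 3 (beyond the scatter) and is a large step even though the oxygen stays on the aromatic ring. Set against a number 1.14 log units higher from compound 1 to compound 2 (beyond the scatter) at the other hydroxy, it shows that putting methyl on a hydroxy oxygen moves the number about as far as removing a hydroxy outright, with compound 2 and compound 3 within the scatter of each other in this assay on their values. Nothing measured here gives a reason for this.

The two steps sit at different hydroxy groups, so the effect of position and the effect of the change are not separated. On these data alone, whether ethyl on this oxygen, or an amine or a carboxylic acid in place of this hydroxy, would move the number further stays open.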